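The compounds below may be only part of what the source reports. "The series", "measured", "known", "first", "only" and "open" are said of these compounds alone.

Measured compounds:
- Compound 1, `O=S(=O)(Nc1ccc(-c2nc3ccccc3o2)cc1)c1cccs1`: in an ADME assay on HEK293 cells (Homo sapiens) for cytotoxicity, read by resazurin assay, with a stated time of 48 h (a lower number here means that less compound is tolerated, a higher number that more compound is tolerated), compound 1 gives > 100000 nM, which is a limit of the assay.
- Compound 2, `O=S(=O)(Nc1ccc(-c2nc3ccccc3o2)cc1)c1ccccc1F`: in this assay compound 2 gives > 100000 nM, again a limit of the assay.
- Compound 3, `COc1ccccc1S(=O)(=O)Nc1ccc(-c2nc3ccccc3o2)cc1`: in this assay compound 3 gives > 100000 nM, also a limit of the assay.

Among the measured compounds shown here, compound 3 therefore stands where the other two stand: all three sit at the same limit, (the limit of > 100000 nM in this assay, at which 3 of the 3 values shown sit), so no compound can be set above or below another. The steps between them, a step that the two limits leave unreadable from compound 1 to compound 2, a step that the two limits leave unreadable from compound 1 to compound 3 and a step that the two limits leave unreadable from compound 2 to compound 3, are all unreadable for that reason, and their sizes stay unknown.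

Compound 4, `O=S(=O)(Nc1ccc(-c2nc3ccccc3o2)cc1)c1ccc(Cl)cc1`, has not yet been measured in this assay. It differs from compound 3 by 4-chlorophenyl in place of 2-methoxyphenyl on a sulfonyl sulfur. The measured steps that bear on this change are the three exchanges on the sulfonyl sulfur, and none of them gave a readable size. What they do show is that three different groups on that sulfur all left the compounds tolerated up to the limit. The expectation for compound 4 is therefore no step beyond the scatter, with a number no higher from compound 3 to compound 4 (the limit leaves the size open) as the estimated change. Compound 4 is expected to give about 100000 nM, somewhere between 50000 nM and 300000 nM, most likely reported once more as a limit.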

Compound 4, half-maximal cytotoxic concentration: > 100000 nM
Compound 4: only a limit was reported; the forecaster's own chance of this, stated with the estimate: 85%; the middle value lies on the limit itself.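

Compound 4 also gives a limit of the assay, so no step from it to compound 1, compound 2 or compound 3 can be read, and none of these compounds can be set above another: the limit of > 100000 nM in this assay, at which 4 of the 4 values shown sit.

The compounds shown leave open where each one's actual value lies in this assay and whether the group on the sulfonyl sulfur affects it.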